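Swapping a fluorine for a chlorine on the benzimidazole-type core

The compounds below may be only part of what the source reports. "The series", "measured", "known", "first", "only" and "open" are said of these compounds alone.

Of the compounds shown here, three have been tested in a functional assay on CHO cells for antagonist activity at sphingosine 1-phosphate receptor 2 (Homo sapiens), read by calcium flux; a higher number here means a weaker inhibitor, a lower number a stronger inhibitor. Compound 1 `O=C(O)Cn1nc(Cc2nc3cc(F)c(OCC4CC4)cc3[nH]2)c2ccccc2c1=O` gives 18 nM in this assay. Compound 2 `O=C(O)Cn1nc(Cn2cc3cc(OCC4CC4)c(Cl)cc3n2)c2ccccc2c1=O` gives 11 nM, a number that sits within the usual scatter of that of compound 1, so the two cannot be told apart. Compound 3 `O=C(O)Cn1nc(CC(=O)Nc2ccc(OC(F)(F)F)c(Cl)c2)c2ccccc2c1=O`, in which an amide-linked aryl group takes the place of the fused bicyclic unit, gives 389 nM, a much higher number than compound 1, beyond the scatter. On the numbers shown, compound 1 therefore stands second highest of the three, close to compound 2 and far from compound 3.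

Compound 4 `O=C(O)Cn1nc(Cc2nc3cc(Cl)c(OCC4CC4)cc3[nH]2)c2ccccc2c1=O` has not yet been measured. Within the data shown here, its single difference from compound 1 is chloro in place of fluoro on an aromatic carbon. Among the measured compounds shown here, no measured pair shows this swap on its own, so the size of the step rests on expectation alone. Compound 2 carries a chloro group on a related core and gives 11 nM, which suggests a chlorine here is at least tolerated. A step from compound 1 to compound 4 of about a 1.4-fold lower number from compound 1 to compound 4 (0.14 log units; within the scatter) is expected, which would lie within the scatter. Compound 4 is estimated to give 13 nM in this assay, with a likely range from 5 nM to 35 nM.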

Compound 4, half-maximal inhibitory concentration: 8.8 nM
Compound 4: middle estimate off by 1.5-fold (0.17 log units), on the high side; the range from low to high includes it.
By their numbers in this assay, from the lowest: compounds 4, 2 and 1 (each within the scatter of the next, the first and the last beyond it); then compound 3.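

In this assay, among these compounds, replacing fluoro with chloro on the aromatic carbon ortho to the cyclopropylmethoxy group gives a 2.0-fold lower number from compound 1 to compound 4 (0.31 log units; beyond the scatter), the first reading of this swap on its own, since no earlier pair isolated it. The step is modest and lies only just beyond the scatter, so this one pair shows that the position accepts either halogen while the number stays low, with a small difference in favour of chloro. Nothing measured here accounts for the difference, so the data give no explanation for it.

The compounds shown leave open how far this position can be changed, since they include neither a bromine, a methyl group, a trifluoromethyl group or a nitrile on this carbon, nor a plain hydrogen there as a baseline with no halogen at all. They also leave open whether the swap from fluoro to chloro would give a similar step if a shorter group such as methoxy, or a longer chain, stood in place of the cyclopropylmethoxy group.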